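The source may report more compounds than this note shows. Statements on the series, on what has been measured and on what is new or still open speak of the compounds shown alone.

Compound 1 `COc1ccc(/C=C/C(=O)/C(C)=C/c2ccccc2)cc1` is the reference point of this small set. In an ADME assay on LLC-MK2 cells (Macaca mulatta) for cytotoxicity, read by MTT assay, with a stated time of 48 h (on this read-out higher numbers stand for lower toxicity in this test and lower numbers for higher toxicity in this test), compound 1 gives 93000 nM, the highest of the two numbers in hand. Going by the values given here, its only measured neighbour is compound 2 `C/C(=C\c1ccccc1)C(=O)/C=C/c1ccc(N(C)C)cc1`, which differs by a dimethylamino in place of methoxy on an aromatic carbon; in this assay compound 2 gives 53000 nM, and the step of a 1.8-fold lower number from compound 1 to compound 2 (0.24 log units; within the scatter) stays within the scatter. Compound 3 `COc1ccc(/C=C/C(=O)/C(C)=C/c2ccc(N(C)C)cc2)cc1` keeps the methoxy of compound 1 and differs from it as follows: dimethylamino in place of hydrogen on an aromatic carbon. Among the compounds with values here, the one measured step that bears on this change is the swap from compound 1 to compound 2, which introduced the same dimethylamino group, though on the other ring and at the cost of the methoxy, and it moved the number by a 1.8-fold lower number from compound 1 to compound 2 (0.24 log units; within the scatter), within the scatter. On that evidence the dimethylamino group is not expected to shift this assay beyond the scatter, and any drift is expected to point toward a lower number, as in the step to compound 2. Compound 3 is therefore estimated at 70000 nM, with a range from 30000 nM to 160000 nM, an expected step of a 1.3-fold lower number from compound 1 to compound 3 (0.12 log units; within the scatter).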

Compound 3, half-maximal cytotoxic concentration: 285000 nM
For compound 3 the middle estimate is 4.1-fold (0.61 log units) below the measured one; the measured number lies above the stated range.
By their numbers in this assay, from the lowest: compounds 2 and 1 (each within the scatter of the next); then compound 3.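

In this assay, the step of a 3.1-fold higher number from compound 1 to compound 3 (0.49 log units; beyond the scatter) shows that dimethylamino in place of hydrogen on an aromatic carbon, para to a large group, can carry the number beyond the scatter, toward lower toxicity in this test. The earlier step of a 1.8-fold lower number from compound 1 to compound 2 (0.24 log units; within the scatter) stayed within the scatter, but there dimethylamino took the place of methoxy, so the two steps differ both in where the group enters and in what leaves, and the earlier step did not show that this position responds to the group. Nothing in hand accounts for the size or direction of the new step.

The compounds shown leave open whether this rise belongs to dimethylamino itself or would also appear with a smaller amine, a methoxy or a carboxylic acid at the same place. Going by these compounds alone, they also leave open whether the same change would give a similar step on a core without the methoxy that compound 1 and compound 3 share, and with only one compound at this position, no trend across groups can yet be drawn.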